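This account rests on a few compounds, and the source may have more. Where it says the series, first, only, none or still open, it means among the compounds named here.

Working notes on the series. For the measured compounds named here, the two compounds measured so far share one core and differ only in the chain on the saturated ring carbon: compound 1 `CC(C)CC1CNCCN1c1ccc2[nH]ncc2c1` carries an isobutyl chain, compound 2 `COCC1CNCCN1c1ccc2[nH]ncc2c1` a methoxymethyl chain. In an assay on HEK293 cells for displacement of a labelled ligand from sodium-dependent dopamine transporter (Homo sapiens), read by scintillation proximity assay (a lower number here means a stronger inhibitor, a higher number a weaker inhibitor), compound 1 gives 15.9 nM, and in this assay compound 2 gives 501 nM. Going by the values given here, the single step between them, a 32-fold higher number from compound 1 to compound 2 (1.50 log units; beyond the scatter), is the only measured step in the set, and it places compound 2 at the weaker end of the two numbers recorded.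

Compound 3 `CCOCC1CNCCN1c1ccc2[nH]ncc2c1` is the next member. Against compound 2 the change is methyl in place of hydrogen on a saturated chain carbon bound to an oxygen on a saturated carbon. Among the compounds with values here, no measured step bears directly on this change; the step from compound 1 to compound 2 concerns a different group on a different carbon and only shows that this region of the molecule can move the number a great deal. With one heavy atom entering, a modest step is expected for compound 3, about a 1.6-fold lower number from compound 2 to compound 3 (0.19 log units; within the scatter), direction uncertain. Compound 3 is estimated at 320 nM in this assay, with a range of 100 nM to 1000 nM.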

Compound 3, inhibition constant: 316 nM
Beside the measured number, compound 3's estimate is 1.0-fold (0.01 log units) above it, within the range that was stated.
By their numbers in this assay, from the lowest: compound 1; then compounds 3 and 2 (each within the scatter of the next).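

In this assay, methyl in place of hydrogen on a saturated chain carbon bound to an oxygen on a saturated carbon gives a 1.6-fold lower number from compound 2 to compound 3 (0.20 log units; within the scatter) and so does not separate the ethoxymethyl chain from the methoxymethyl chain. Compound 3 also remains far from the isobutyl compound, with a 20-fold higher number from compound 1 to compound 3 (1.30 log units; beyond the scatter), so the added methyl does not close the large gap seen with methoxymethyl, and both ether chains stand apart from compound 1. Nothing available here bears on the reason for these numbers.

On these data alone, whether a longer chain on the oxygen, such as propoxy or butoxy, would stay with compound 2 and compound 3 or move towards compound 1 remains open. So does the outcome with an amine or a hydroxyl group at the end of this chain.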